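Adding a Methyl Twice: One Place Known, One Not

The compounds below may be only part of what the source reports. "The series", "measured", "known", "first", "only" and "open" are said of these compounds alone.

Compound 1 `CCNc1nc(C)nc(O)c1C#N` and compound 2 `CCCNc1nc(C)nc(O)c1C#N` share a core and differ only by methyl in place of hydrogen on a saturated chain carbon, two bonds along the chain from a nitrogen on an aromatic ring. In a functional assay with Felis catus as the target (a lower number here means that less compound is needed, a higher number that more compound is needed for the effect), compound 1 gives 300000 nM, and compound 2 gives 17000 nM, a difference of an 18-fold lower number from compound 1 to compound 2 (1.25 log units; beyond the scatter). Compound 3 `CC(C)c1nc(O)c(C#N)c(NCc2cccnc2)n1` is built on another core; the difference between the two cores is not broken down here. In this assay compound 3 gives 10000 nM, which sits within the scatter of compound 2 and well away from compound 1. Compound 4 `CC(C)(C)c1nc(O)c(C#N)c(NCc2cccnc2)n1` differs from compound 3 by methyl in place of hydrogen on a saturated chain carbon bound to an aromatic carbon and two saturated chain carbons. This is the same kind of change as that from compound 1 to compound 2, but not the same: there the methyl entered on a saturated chain carbon two bonds along the chain from a nitrogen on an aromatic ring, here it enters on a saturated chain carbon bound to an aromatic carbon and two saturated chain carbons. Because the earlier step of an 18-fold lower number from compound 1 to compound 2 (1.25 log units; beyond the scatter) was large but made at a different place, compound 4 is expected to improve only modestly, by a 2.0-fold lower number from compound 3 to compound 4 (0.30 log units; within the scatter). Compound 4 is therefore estimated at 5000 nM, between 1000 nM and 25000 nM.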

Compound 4, half-maximal effective concentration: 110000 nM
Estimate against measurement, compound 4: 22-fold (1.34 log units) below; measured number above the stated range.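

Carrying this change from one core to another in this series does not preserve its effect. In this assay the added methyl, which lowered the number on the core of compound 1, goes the other way on the core of compound 3, with an 11-fold higher number from compound 3 to compound 4 (1.04 log units; beyond the scatter) as isopropyl gives way to tert-butyl. The two steps clearly disagree in direction: the same change on two cores in this assay, an 18-fold lower number (1.25 log units; beyond the scatter) from compound 1 to compound 2 and an 11-fold higher number (1.04 log units; beyond the scatter) from compound 3 to compound 4, 190-fold (2.29 log units) apart, beyond the scatter of two such steps. Going by these compounds alone, this shows that the earlier step cannot be transferred as it stands, but it does not show whether the core or the place of the methyl decides the outcome, since the two pairs differ in both and only one pair stands on each core.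

The compounds shown leave open how the number would respond to a cyclopropyl group or a longer chain on the saturated chain carbon bound to an aromatic carbon. They also leave open whether a methyl added at one fixed place would give steps of the same direction on both cores.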